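The source may report more compounds than this note shows. Statements on the series, on what has been measured and on what is new or still open speak of the compounds shown alone.

Three esters of the shared core have been measured: compound 1 `CCC(=O)OCCc1c(-c2ccccc2Cl)c2cc(Cl)ccc2[nH]c1=O`, compound 2 `CCCCCCCC(=O)OCCc1c(-c2ccccc2Cl)c2cc(Cl)ccc2[nH]c1=O` and compound 3 `O=C(OCCc1c(-c2ccccc2Cl)c2cc(Cl)ccc2[nH]c1=O)c1cccs1`. In an ADME assay on HepG2 2.2.15 cells (Homo sapiens) for cytotoxicity (on this read-out lower numbers stand for higher toxicity in this test and higher numbers for lower toxicity in this test), compound 1 gives 95000 nM and compound 2 gives 78000 nM, a step of a 1.2-fold lower number from compound 1 to compound 2 (0.09 log units; within the scatter). Compound 3 reaches only a limit of this assay, > 1700000 nM, so its number is not known exactly (the limit of > 1700000 nM in this assay, at which 1 of the 3 values shown sits). The steps into it, an at least 17-fold higher number from compound 1 to compound 3 (1.25 log units; beyond the scatter) and an at least 21-fold higher number from compound 2 to compound 3 (1.33 log units; beyond the scatter), place compound 3 highest among the three, although only as a limit.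

Compound 4 `C/C=C(\C)C(=O)OCCc1c(-c2ccccc2Cl)c2cc(Cl)ccc2[nH]c1=O` is the next ester in the series. 1-methylprop-1-en-1-yl in place of thiophen-2-yl on a carbonyl carbon The entering group is a short open chain, closer in kind to the ethyl and heptyl groups of compounds 1 and 2 than to the ring it replaces. Both steps into compound 3 were large and pointed the same way, so the step out of compound 3 toward an open chain is expected to run back toward the numbers of compounds 1 and 2, with wide uncertainty because compound 3 gives only the limit > 1700000 nM. Compound 4 is therefore expected to give about 300000 nM in this assay, within 80000 nM to 1700000 nM. The expected step is an at least 5.6-fold lower number from compound 3 to compound 4 (0.75 log units; beyond the scatter).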

Compound 4, half-maximal cytotoxic concentration: 350000 nM
Beside the measured number, compound 4's estimate is 1.2-fold (0.07 log units) below it; the measured number falls inside the stated range.
By their numbers in this assay, from the lowest: compounds 2 and 1 (each within the scatter of the next); then compound 4. At a limit, above all of these: compound 3.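

Among the compounds shown here, at this position on a carbonyl carbon, the earlier compounds showed two saturated chains, ethyl and heptyl, whose numbers lay within the scatter of each other, and a ring far above them. In this assay, 1-methylprop-1-en-1-yl now opens an intermediate level, with a 3.7-fold higher number from compound 1 to compound 4 (0.57 log units; beyond the scatter) and a 4.5-fold higher number from compound 2 to compound 4 (0.65 log units; beyond the scatter), so an open chain on this carbon does not have to fall back to the numbers of compound 1 and compound 2. All the same, the change from thiophen-2-yl to this chain, which has a double bond and no ring, lowers the number, with an at least 4.8-fold lower number from compound 3 to compound 4 (0.68 log units; beyond the scatter), and the full size of that step cannot be read because compound 3 stands at a limit: the limit of > 1700000 nM in this assay, at which 1 of the 4 values shown sits.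

On these data alone, it remains open whether the level of compound 4 goes with the double bond or with the branch in the chain, a question that a saturated butan-2-yl group on the same carbon would address. As far as these compounds go, it is also open whether another ring, such as phenyl or furan-2-yl, would rise as far as thiophen-2-yl does.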